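From bromofluorophenyl to trifluoromethylphenyl on the shared core

A few compounds are considered here, and "the series" means these few. Any claim that something is new, unique, unknown or untested is made for them only; others in the source may bear on it.

Measured compounds:
- compound 1 `CCNC(=O)c1cc(Oc2ccc(NC(=O)c3nn(-c4ccc(Br)cc4F)c(=O)cc3C)cc2)ccn1` gives 34500 nM
- compound 2 `CNC(=O)c1cc(Oc2ccc(NC(=O)c3nn(-c4ccccc4Cl)c(=O)cc3C)cc2F)ccn1` gives 11800 nM
- compound 3 `CCCNC(=O)c1cc(Oc2ccc(NC(=O)c3nn(-c4ccccc4OC(F)(F)F)c(=O)cc3C)cc2F)ccn1` gives 4220 nM

All three values come from a functional assay on A549 cells (Homo sapiens) for antiproliferative activity, read by MTT assay, with a stated time of 72 h (a lower number here means a stronger inhibitor, a higher number a weaker inhibitor), and show the antiproliferative activity of each compound. Compound 1 has the highest number of the three, which makes it the weakest inhibitor here, and its gaps to both others lie beyond the usual scatter.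

The next molecule, compound 4 `CCNC(=O)c1cc(Oc2ccc(NC(=O)c3nn(-c4cccc(C(F)(F)F)c4)c(=O)cc3C)cc2)ccn1`, carries 3-(trifluoromethyl)phenyl in place of 4-bromo-2-fluorophenyl on an aromatic nitrogen and keeps the rest of compound 1 unchanged.

Among the measured compounds shown here, no two measured compounds differ in only one place, so the data give no direct guide to this change. Compound 2 (11800 nM) and compound 3 (4220 nM) have other groups at this nitrogen and lower numbers, but they also differ elsewhere. A modest move toward a lower number is therefore expected, with an estimated size of a 2.9-fold lower number from compound 1 to compound 4 (0.46 log units; beyond the scatter) in this assay, though this is uncertain. The expected value for compound 4 is 12000 nM within an estimated range (3500 nM to 40000 nM).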

Compound 4, half-maximal inhibitory concentration: 10000 nM
The estimate for compound 4 lay 1.2-fold (0.08 log units) above the measured number; measured number inside the range.
By their numbers in this assay, from the lowest: compound 3; then compounds 4 and 2 (each within the scatter of the next); then compound 1.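

In this assay, among the compounds shown here, replacing 4-bromo-2-fluorophenyl with 3-(trifluoromethyl)phenyl on the aromatic nitrogen gives a 3.5-fold lower number from compound 1 to compound 4 (0.54 log units; beyond the scatter) and provides the first direct reading of this position. The earlier compounds shown here differed from one another in more than one place, whereas here the rest of compound 1 stays unchanged, so the group on this nitrogen alone can shift the number. No supporting measurement accompanies this result to explain the shift.

On these data alone, this single step removes the bromine and fluorine and adds the trifluoromethyl group all at once, so the contribution of each remains unknown. As far as these compounds go, it also remains open how the number would respond to a plain phenyl group or to a phenyl ring carrying a nitrile or a methoxy group on this nitrogen.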